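Swapping a chain end for an ether on a lactam

This account rests on a few compounds, and the source may have more. Where it says the series, first, only, none or still open, it means among the compounds named here.

Of the compounds shown here, two have so far been measured in an assay on HEK293 cells for inhibition of N-acylethanolamine-hydrolyzing acid amidase (Homo sapiens), read by fluorescence, with stated times of 10 min and 50 min; a higher number here means a weaker inhibitor, a lower number a stronger inhibitor. Compound 1 `CON1C[C@H](NC(=O)OCCCCC2CCCCC2)C1=O` gives 16 nM. Compound 2 `CCCCCON1C(=O)[C@@H](NC(=O)OCCCCC2CCCCC2)[C@@H]1C` gives 387 nM, the higher of the two numbers, and its gap to compound 1 lies beyond the usual scatter. The two differ in more than one place, so only their values are known, not a single step.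

Compound 3 `CCOCCON1C(=O)[C@@H](NC(=O)OCCCCC2CCCCC2)[C@@H]1C` has not yet been measured. It differs from compound 2 by ethoxy in place of propyl on a saturated chain carbon, two bonds along the chain from an oxygen on an unsaturated carbon. Within the data shown here, no measured pair shows this particular change, so the expectation rests on compound 2 alone, whose value of 387 nM is the only anchor. The step of a 1.5-fold lower number from compound 2 to compound 3 (0.19 log units; within the scatter) is expected to be small, most likely within the scatter, with a slight lean toward a lower number. Compound 3 is therefore estimated at 250 nM, with a range from 80 nM to 800 nM.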

Compound 3, half-maximal inhibitory concentration: 187 nM
Compound 3: middle estimate off by 1.3-fold (0.13 log units), on the high side; the range from low to high includes it.
By their numbers in this assay, from the lowest: compound 1; then compound 3; then compound 2.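

In this assay, ethoxy in place of propyl on this saturated chain carbon gives a 2.1-fold lower number from compound 2 to compound 3 (0.32 log units; beyond the scatter), a modest step that lies just beyond the usual scatter. This shows that the position responds to the change, and that a 2-ethoxyethoxy chain is accepted at least as well as the pentyloxy chain it replaces, with an oxygen in the chain and one more hydrogen-bond acceptor. Nothing available explains why the number falls.

As far as these compounds go, with a single pair, it remains open whether the same swap would act alike on another core, or how an amine or a longer chain would fare at this carbon. Compound 3 also differs from compound 1 in more than one place, so the gap between their values cannot be traced to any single change.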